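A few compounds are considered here, and "the series" means these few. Any claim that something is new, unique, unknown or untested is made for them only; others in the source may bear on it.

Measured compounds:
compound 1 `Cn1nnnc1SCC(=O)N/N=C/c1ccc(F)cc1` — 10000000 nM
compound 2 `Cn1nnnc1SCC(=O)N/N=C/c1ccccc1[N+](=O)[O-]` — 2020000 nM

In an ADME assay on NIH3T3 cells (Mus musculus) for cytotoxicity, read by XTT assay, with a stated time of 24 h (a lower number here means a stronger inhibitor, a higher number a weaker inhibitor), compound 2 gives the lowest of the two numbers measured, and compound 1 gives a higher one; the gap between compound 1 and compound 2 lies beyond the scatter of repeated measurements. Compound 3 `Cn1nnnc1SCC(=O)N/N=C/c1ccccc1Br` has not yet been measured. It differs from compound 2 in one place: bromo in place of nitro on an aromatic carbon. For the measured compounds named here, no step between measured compounds resembles this exchange, so nothing measured shows which way it will go. Both measured values are weak, and the expectation for compound 3 is that it stays in that weak region. The step of a 1.5-fold higher number from compound 2 to compound 3 (0.17 log units; within the scatter) is expected to be small, within the scatter or leaning toward a higher number. Compound 3 is therefore estimated at 3000000 nM, with a range from 700000 nM to 10000000 nM.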

Compound 3, half-maximal inhibitory concentration: 20000 nM
Compound 3: middle estimate off by 150-fold (2.18 log units), on the high side, outside the stated range (below it).
By their numbers in this assay, from the lowest: compound 3; then compound 2; then compound 1.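

Exchanging nitro for bromo on an aromatic carbon, ortho to a large group, gives a 100-fold lower number from compound 2 to compound 3 (2.00 log units; beyond the scatter) in this assay. For the compounds shown here, this shows that the number in this assay depends strongly on what this position of the six-membered aromatic ring carries, since one exchange there moves it far beyond the scatter, which no earlier step could show. Nothing measured here explains the size of this step, and this single exchange gives no basis for linking it to any one difference between nitro and bromo.

The compounds shown leave open whether chloro, methoxy or an amine at this same place would give a number close to that of compound 3 or that of compound 2. They also leave open whether bromo would have a comparable effect elsewhere on the ring.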